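The source may report more compounds than this note shows. Statements on the series, on what has been measured and on what is new or still open speak of the compounds shown alone.

Compound 1 `COc1cc(/C=C/C(=O)c2cccc(NC(=O)c3cc(Cl)cc(Cl)c3)c2)ccc1O` in a functional assay on Vero cells (Chlorocebus sabaeus) for inhibition (a lower number here means a stronger inhibitor, a higher number a weaker inhibitor), gives only a limit, > 50 ug/mL.
Compound 2 `COc1cc(/C=C/C(=O)c2cccc(NC(=O)c3c(Cl)cccc3Cl)c2)ccc1O` gives 2.48 ug/mL.

Compound 2 thus holds the only number shown; the other value sits at the limit of > 50 ug/mL in this assay, at which 1 of the 2 values shown sits. Compound 3 `COc1cc(/C=C/C(=O)c2cccc(NC(C)=O)c2)ccc1O` differs from compound 2 as follows: methyl in place of 2,6-dichlorophenyl on a carbonyl carbon. Among the measured compounds shown here, the one measured step, an at least 20-fold lower number from compound 1 to compound 2 (1.30 log units; beyond the scatter), moves the chlorines within the aromatic ring and keeps that ring, so it bears only loosely on a change that removes the ring altogether. A weaker number, beyond the scatter, is expected, with a fair chance of a limit only. Compound 3 is estimated at 15 ug/mL, range 4 ug/mL to 50 ug/mL, an expected step of a 6.0-fold higher number from compound 2 to compound 3 (0.78 log units; beyond the scatter).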

Compound 3, half-maximal inhibitory concentration: 14.5 ug/mL
Beside the measured number, compound 3's estimate is 1.0-fold (0.01 log units) above it, and the stated range covers the measured number.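

In this assay, the carbonyl carbon tolerates loss of the aromatic ring without loss of a measurable number: compound 3, with methyl there, gives 14.5 ug/mL. Methyl falls between the two dichlorophenyl isomers, with a 5.8-fold higher number from compound 2 to compound 3 (0.77 log units; beyond the scatter) and an at least 3.4-fold lower number from compound 1 to compound 3 (0.53 log units; beyond the scatter). The second of these steps rests on a limit, as compound 1 gives no number: the limit of > 50 ug/mL in this assay, at which 1 of the 3 values shown sits.

The compounds shown leave open how an unsubstituted phenyl, a longer alkyl chain or an amine on this carbonyl carbon would read. From the compounds shown here alone, whether one chlorine in the 2-position would suffice also remains open.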